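Working notes on the 2-fluorobenzyl to 3-cyanobenzyl step

The source may hold more compounds than are shown below. What is called first, only, known or untested is meant among the compounds shown, and "the series" means these compounds.

Measured so far in an in vitro functional assay on cells for agonist activity at Bombesin receptor subtype-3 (Homo sapiens), read by luminescence and calcium flux; a higher number here means that more compound is needed for the effect, a lower number that less compound is needed:
Compound 1, `CCCCc1cnc(C(CCC)Cc2ccc(-c3ccccc3C(=O)O)cc2)[nH]1`, gives 1180 nM.
Compound 2, `CCCCc1cnc(C(CCCC)Cc2ccc(-c3ccccc3C(=O)O)cc2)[nH]1`, gives 2660 nM.
Compound 3, `O=C(O)c1ccccc1-c1ccc(CCc2ncc(Cc3ccccc3F)[nH]2)cc1`, gives 177 nM.

Compound 3 holds the lowest number of the three, and its distance to both compound 1 and compound 2 lies beyond the scatter. Among the compounds with values here, the only step between measured compounds is a 2.3-fold higher number from compound 1 to compound 2 (0.35 log units; beyond the scatter), a modest change on the saturated chain that is remote from the part altered here.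

Compound 4, `N#Cc1cccc(Cc2cnc(CCc3ccc(-c4ccccc4C(=O)O)cc3)[nH]2)c1`, differs from compound 3 in one place: 3-cyanophenyl in place of 2-fluorophenyl on a saturated chain carbon bound to an aromatic carbon. Within the data shown here, no measured step bears on this exchange; the step from compound 1 to compound 2 touches a different part of the molecule, and compound 3 is the only measured compound carrying the 2-fluorophenyl group, so nothing anchors the direction. With no guidance from the series, a step of a 1.7-fold higher number from compound 3 to compound 4 (0.23 log units; within the scatter) is expected, small and uncertain in direction. Compound 4 is therefore estimated at 300 nM, with a range from 80 nM to 1200 nM in this assay.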

Compound 4, half-maximal effective concentration: 812 nM
Compound 4: middle estimate off by 2.7-fold (0.43 log units), on the low side, within the range that was stated.
By their numbers in this assay, from the lowest: compound 3; then compounds 4 and 1 (each within the scatter of the next); then compound 2.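

The 2-fluorophenyl site, on a saturated chain carbon bound to an aromatic carbon, is not indifferent to the group it carries: the exchange for 3-cyanophenyl gives a 4.6-fold higher number from compound 3 to compound 4 (0.66 log units; beyond the scatter). Within the data shown here, the earlier compounds showed only a change on a saturated chain, so this is the first reading of a change to this aromatic group, and here the 2-fluorophenyl compound keeps the lower number. Nothing available bears on what lies behind this step.

The exchange replaces the fluorine with a nitrile and also changes the name's ring position, so the compounds shown cannot separate these two changes. Also open, from the compounds shown here alone, is how a plain benzyl group, or a methoxy or chlorine on this ring, would compare with compound 3 and compound 4.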